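This account rests on a few compounds, and the source may have more. Where it says the series, first, only, none or still open, it means among the compounds named here.

Three compounds of the series have been run in a functional assay on HepG2 cells (Homo sapiens) for antiproliferative activity, read by MTT assay, with a stated time of 48 h (a higher number here means a weaker inhibitor, a lower number a stronger inhibitor), so far. Compound 1 `Cc1ccc(C(=O)Nc2ccc(Cl)cc2C(N)=O)cc1` gives 21 ug/mL, compound 3 `Cc1ccc(-c2nc3ccc(Cl)cc3c(=O)n2N)cc1` gives 18.4 ug/mL, and compound 2 `Cc1ccc(-c2nc(NN)c3cc(Cl)ccc3n2)cc1` gives 4.17 ug/mL, which is the lowest of the three numbers and stands beyond the scatter from both others. The next compound, compound 4 `Cc1ccc(-c2nc(SCC#N)c3cc(Cl)ccc3n2)cc1`, differs from compound 2 in one place: (cyanomethyl)sulfanyl in place of aminoamino on an aromatic carbon. Among the compounds with values here, no pair of measured compounds shows this change, so its size in this assay is unknown. The expectation for compound 4 is a modest loss, roughly at the edge of the scatter, giving an estimated step of a 1.9-fold higher number from compound 2 to compound 4 (0.28 log units; within the scatter). Compound 4 is therefore estimated at 8 ug/mL, within a range of 3 ug/mL to 25 ug/mL.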

Compound 4, half-maximal inhibitory concentration: 4.37 ug/mL
For compound 4 the middle estimate is 1.8-fold (0.26 log units) above the measured one; measured number inside the range.
By their numbers in this assay, from the lowest: compounds 2 and 4 (each within the scatter of the next); then compounds 3 and 1 (each within the scatter of the next).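

In this assay, (cyanomethyl)sulfanyl in place of aminoamino on this aromatic carbon next to the ring nitrogen gives a 1.0-fold higher number from compound 2 to compound 4 (0.02 log units; within the scatter) as the step. The position thus accepts a larger entering group with 0 hydrogen-bond donors in place of one with 2, and in this pair hydrogen-bond donors on the substituent are not required to hold the read-out. Open, going by these compounds, is whether a plain amine, a carboxylic acid or a longer chain on the sulfur would hold the same level at this carbon. Also open, on these data alone, is whether the nitrile contributes at all, which a simple methylsulfanyl group would address. No supporting measurement bears on why this pair matches.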